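Phenyl for Nitro: Estimating Compound 4 Against Aromatase

This account rests on a few compounds, and the source may have more. Where it says the series, first, only, none or still open, it means among the compounds named here.

Of the compounds shown here, three have been measured in an assay on isolated protein for inhibition of Aromatase (Homo sapiens), read by fluorescence and colorimetric assay, with a stated time of 30 min; a lower number here means a stronger inhibitor, a higher number a weaker inhibitor. Compound 3 `O=[N+]([O-])c1ccc(OCc2cn(C(c3ccccc3)c3ccccc3)nn2)cc1` gives 11600 nM. Compound 1 `N#Cc1ccc(C(c2ccc(C#N)cc2)n2cc(COc3ccccc3)nn2)cc1` gives 11000 nM, and compound 2 `Clc1ccc(OCc2cn(C(c3ccccc3)c3ccccc3)nn2)cc1` gives 13400 nM. All three sit within the scatter of one another, so none can be called stronger or weaker than the others. Among the compounds with values here, the only single-point step among them, a 1.2-fold lower number from compound 2 to compound 3 (0.06 log units; within the scatter), stayed within the scatter. Compound 4 `c1ccc(-c2ccc(OCc3cn(C(c4ccccc4)c4ccccc4)nn3)cc2)cc1` differs from compound 3 by phenyl in place of nitro on an aromatic carbon. Within the data shown here, no measured pair exchanges a nitro for a phenyl, so the sole guide is that the one swap at this position left this assay unchanged. A small step is therefore expected, a 1.3-fold lower number from compound 3 to compound 4 (0.11 log units; within the scatter). Compound 4 is estimated at 9000 nM, with a range from 3500 nM to 25000 nM.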

Compound 4, half-maximal inhibitory concentration: 15500 nM
Estimate against measurement, compound 4: 1.7-fold (0.24 log units) below, within the range that was stated.
By their numbers in this assay, from the lowest: compounds 1, 3, 2 and 4 (each within the scatter of the next).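

Replacing nitro with a whole aromatic ring of carbon only, on an aromatic carbon para to a large group, still produces no readable change in this assay: there is a 1.3-fold higher number from compound 3 to compound 4 (0.13 log units; within the scatter), and a 1.2-fold higher number from compound 2 to compound 4 (0.06 log units; within the scatter). Chloro, nitro and phenyl thus cannot be told apart at this position, even though phenyl is the only one of the three that brings a ring. Nothing available explains this flat result. Going by these compounds, whether an amine or a carboxylic acid here would move the number remains open. So does whether these swaps would behave alike on the core of compound 1.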